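Trading an aromatic ring for a saturated one

The source may hold more compounds than are shown below. What is called first, only, known or untested is meant among the compounds shown, and "the series" means these compounds.

Three compounds share one core and differ only in the group on a saturated chain carbon bound to an oxygen on a saturated carbon. Compound 1 `CC(C)(N)C(=O)N[C@H](COCc1ccc(F)cc1F)c1nnnn1CCOC(=O)NCCCCO` gives 0.42 nM in a functional assay on cells for inhibition of growth hormone secretagogue receptor type 1 (Homo sapiens), read by FLIPR and calcium flux; a lower number here means that less compound is needed, a higher number that more compound is needed for the effect. Compound 2 `CC(C)(N)C(=O)N[C@H](COCc1ccc(OC(F)(F)F)cc1)c1nnnn1CCOC(=O)NCCCCO` gives 33.2 nM, and compound 3 `COc1ccccc1COC[C@@H](NC(=O)C(C)(C)N)c1nnnn1CCOC(=O)NCCCCO` gives 1.11 nM. Compound 3 thus holds the second highest of the three numbers: the step of a 2.6-fold higher number from compound 1 to compound 3 (0.42 log units; beyond the scatter) is modest, while a 30-fold lower number from compound 2 to compound 3 (1.48 log units; beyond the scatter) is large, as is a 79-fold higher number from compound 1 to compound 2 (1.90 log units; beyond the scatter).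

Compound 4 `CC(C)(N)C(=O)N[C@H](COCC1CCCCC1)c1nnnn1CCOC(=O)NCCCCO` carries cyclohexyl in place of 2-methoxyphenyl on a saturated chain carbon bound to an oxygen on a saturated carbon. Among the measured compounds shown here, every measured step swaps one aromatic group for another at this position, and their sizes ran from modest to large; none replaces the aromatic ring with a non-aromatic one, so the direction of the step to compound 4 has no direct precedent. Given that swaps at this position have never been silent, a step at least as large as a 2.6-fold higher number from compound 1 to compound 3 (0.42 log units; beyond the scatter) is expected, leaning toward a higher number: compound 4 is estimated at 5 nM, within 1 nM to 40 nM, a step of a 4.5-fold higher number from compound 3 to compound 4 (0.65 log units; beyond the scatter).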

Compound 4, half-maximal effective concentration: 1.66 nM
Beside the measured number, compound 4's estimate is 3.0-fold (0.48 log units) above it; the measured number falls inside the stated range.
By their numbers in this assay, from the lowest: compound 1; then compounds 3 and 4 (each within the scatter of the next); then compound 2.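

In this assay, the position accepts a non-aromatic ring: putting cyclohexyl in place of 2-methoxyphenyl gives a step within the scatter (a 1.5-fold higher number from compound 3 to compound 4 (0.17 log units; within the scatter)), so an aromatic ring is not needed here for a single-digit nanomolar number. The same cyclohexyl group stands far from 4-(trifluoromethoxy)phenyl (a 20-fold lower number from compound 2 to compound 4 (1.30 log units; beyond the scatter)) but does not match 2,4-difluorophenyl (a 4.0-fold higher number from compound 1 to compound 4 (0.60 log units; beyond the scatter)), so the saturated ring falls among the aromatic groups rather than outside their range. Nothing available explains why these groups rank as they do.

Only one saturated ring is shown, so it remains open whether a cyclopentyl ring, a piperidine or an open butyl chain would behave like cyclohexyl. As far as these compounds go, it is equally open whether fluorine atoms on the cyclohexyl ring would close the remaining step to compound 1.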